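The source may hold more compounds than are shown below. What is called first, only, known or untested is meant among the compounds shown, and "the series" means these compounds.

Three members of the series share one core and differ only in the aryl group on the amine nitrogen. In a functional assay on DU-145 cells (Homo sapiens) for cytotoxicity, read by MTT assay, with a stated time of 48 h (a lower number here means a stronger inhibitor, a higher number a weaker inhibitor), compound 1 `Cc1ccc(S(=O)(=O)/N=C(/CCNC2=CC(=O)c3ccccc3C2=O)Nc2ccc(F)cc2)cc1` gives 12200 nM, the lowest of the three numbers. Compound 2 `COc1ccc(N/C(CCNC2=CC(=O)c3ccccc3C2=O)=N\S(=O)(=O)c2ccc(C)cc2)cc1OC` gives 17800 nM, and compound 3 `COc1ccc(N/C(CCNC2=CC(=O)c3ccccc3C2=O)=N\S(=O)(=O)c2ccc(C)cc2)c(OC)c1` gives 67300 nM. The step of a 1.5-fold higher number from compound 1 to compound 2 (0.16 log units; within the scatter) lies within the scatter, while a 5.5-fold higher number from compound 1 to compound 3 (0.74 log units; beyond the scatter) and a 3.8-fold higher number from compound 2 to compound 3 (0.58 log units; beyond the scatter) go beyond it. Compound 4 `Cc1ccc(S(=O)(=O)/N=C(/CCNC2=CC(=O)c3ccccc3C2=O)Nc2cc(F)c(F)c(F)c2)cc1` is not yet measured; relative to compound 1 it has 3,4,5-trifluorophenyl in place of 4-fluorophenyl on an amine nitrogen. Both measured steps at this nitrogen came out flat or weaker, and none of them alters the fluorine count, so the bearing on compound 4 is loose. In this assay compound 4 is therefore expected near compound 1 or somewhat weaker, a 1.3-fold higher number from compound 1 to compound 4 (0.12 log units; within the scatter). The estimate for compound 4 is 16000 nM, ranging from 6000 nM to 45000 nM.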

Compound 4, half-maximal inhibitory concentration: 12600 nM
Compound 4: the middle estimate sits 1.3-fold (0.10 log units) above what was measured; low and high end bracket the measured number.
By their numbers in this assay, from the lowest: compounds 1, 4 and 2 (each within the scatter of the next); then compound 3.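

In this assay, 3,4,5-trifluorophenyl and 4-fluorophenyl on the amine nitrogen cannot be told apart (a 1.0-fold higher number from compound 1 to compound 4 (0.01 log units; within the scatter)), so the added fluorines bring no readable difference. 3,4,5-Trifluorophenyl is likewise level with 3,4-dimethoxyphenyl (a 1.4-fold lower number from compound 2 to compound 4 (0.15 log units; within the scatter)), and among these compounds only 2,4-dimethoxyphenyl stands apart (a 5.3-fold lower number from compound 3 to compound 4 (0.73 log units; beyond the scatter)). No measurement at hand accounts for this pattern. Open, going by these compounds, is how an unsubstituted phenyl, or a phenyl carrying a trifluoromethyl or nitrile group, would read at this nitrogen. Also open, on these data alone, is whether a single methoxy group on the phenyl would separate from the fluorinated aryl groups.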